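The source may report more compounds than this note shows. Statements on the series, on what has been measured and on what is new or still open speak of the compounds shown alone.

Series notes. The shared core is carried by compound 1 `CS(=O)(=O)c1ccc(Nc2ncc(F)c(Nc3nc4ccccc4s3)n2)cc1`, compound 2 `NS(=O)(=O)c1ccc(Nc2ncc(F)c(Nc3nc4ccccc4s3)n2)cc1`, compound 3 `COc1ccc2nc(Nc3nc(Nc4ccc(S(N)(=O)=O)cc4)ncc3F)sc2c1` and the as yet unmeasured compound 4 `NS(=O)(=O)c1ccc(Nc2nccc(Nc3nc4ccccc4s3)n2)cc1`. In a functional assay on MCF7 cells (Homo sapiens) for antiproliferative activity, read by MTT assay, with a stated time of 48 h (on this read-out lower numbers stand for stronger inhibition and higher numbers for weaker inhibition), compound 1 gives 6880 nM. In this assay compound 2 gives only a limit of the assay, > 50000 nM. In this assay compound 3 likewise gives only a limit, > 50000 nM. Within the data shown here, the one readable step, an at least 7.2-fold higher number from compound 1 to compound 2 (0.86 log units; beyond the scatter), is at least modest and runs toward weaker inhibition; the step that the two limits leave unreadable from compound 2 to compound 3 cannot be sized. Compound 2 therefore stands at the limit of > 50000 nM in this assay, at which 2 of the 3 values shown sit, with no number of its own to anchor a comparison.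

The change to compound 4 is hydrogen in place of fluoro on an aromatic carbon. Among the measured compounds shown here, no measured step touches this position: the two steps known concern the group on the sulfonyl sulfur and the methoxy on the other aromatic carbon. Neither tells whether removing the fluoro moves the read-out away from the limit. For the measured compounds named here, with compound 2 itself at a limit, the starting point is unknown, so the expected step that the limit leaves unreadable from compound 2 to compound 4 rests on no measured precedent and is set close to no change. Compound 4 is expected to give 60000 nM in this assay, with a range from 15000 nM to 200000 nM, and most probably to return only a limit once more.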

Compound 4, half-maximal inhibitory concentration: 15300 nM
Beside the measured number, compound 4's estimate is 3.9-fold (0.59 log units) above it; the range from low to high includes it.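

In this assay, among these compounds, hydrogen in place of fluoro on this aromatic carbon, two atoms from the ring nitrogen, gives an at least 3.2-fold lower number from compound 2 to compound 4 (0.51 log units; beyond the scatter), so this position does bear on the read-out, which the earlier steps could not show. Among the compounds shown, compound 4 is the only one with amino on the sulfonyl sulfur to return a number instead of a limit, so amino at that sulfur does not by itself hold a compound at the limit. The step has a size on one side only, since compound 2 has no number of its own: the limit of > 50000 nM in this assay, at which 2 of the 4 values shown sit.

Going by these compounds, the step from compound 2 to compound 3 cannot be read, and whether hydrogen in place of fluoro acts the same way with methyl on the sulfonyl sulfur, as in compound 1, or with the methoxy of compound 3, stays open. The compounds shown also do not tell how chloro, methyl or an amine on this aromatic carbon would compare with hydrogen or fluoro.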